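Shortening the Branched Chain of Compound 1

The source may hold more compounds than are shown below. What is called first, only, known or untested is meant among the compounds shown, and "the series" means these compounds.

Compound 1 `Cc1ccc(OCC(=O)N(Cc2cccs2)CC(C)C)cc1` was tested in an assay on HEK293 cells for agonist activity at transient receptor potential cation channel subfamily M member 8 (Homo sapiens), read by fluorescence and calcium flux, with a stated time of 15 min (a lower number here means that less compound is needed, a higher number that more compound is needed for the effect), where compound 1 gives 900 nM. Among the three compounds measured so far, compound 1 holds the second highest number. Compound 2 `CCN(Cc1cccs1)C(=O)COc1ccc(C#N)cc1` lies closest to it, since compound 2 gives 1990 nM, a difference that goes beyond the usual scatter. Compound 3 `CCN(Cc1cccs1)C(=O)COc1ccc2c(c1)CCC2`, with a differently built aromatic part, gives 0.8 nM, far below the other two.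

Compound 4 `CCCN(Cc1cccs1)C(=O)COc1ccc(C)cc1` keeps the aromatic part of compound 1 and alters only the chain on the amide nitrogen: hydrogen in place of methyl on a saturated chain carbon bound to two saturated chain carbons. Put another way, isobutyl becomes propyl. Among the measured compounds shown here, no measured pair shows the effect of this particular change, so the expected step from compound 1 to compound 4 rests on the change alone and is expected to be small, no change at the digits printed from compound 1 to compound 4 (within the scatter), with no direction beyond the scatter. Compound 4 is therefore estimated at 900 nM, within a range from 300 nM to 3000 nM.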

Compound 4, half-maximal effective concentration: 40 nM
Estimate against measurement, compound 4: 23-fold (1.35 log units) above; the whole stated range lies above it.
By their numbers in this assay, from the lowest: compound 3; then compound 4; then compound 1; then compound 2.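

Hydrogen in place of methyl on a saturated chain carbon bound to two saturated chain carbons, the change of isobutyl to propyl, gives a 23-fold lower number from compound 1 to compound 4 (1.35 log units; beyond the scatter) in this assay, a large step. Among the compounds shown here, no earlier pair offered a step of this kind, so this is the first sign that the chain alone, and not only the aromatic part, can move the number far beyond the scatter, here through the loss of a single carbon. Nothing available explains why this change has so large an effect.

From the compounds shown here alone, one step gives no trend, so it remains open whether ethyl with the aromatic part of compound 4 would continue this direction, or whether a longer chain such as butyl would reverse it. Also open, going by these compounds, are the effect of an amine or a carboxylic acid on this chain, and whether the same change would act alike with the aromatic part of compound 3.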